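The source may report more compounds than this note shows. Statements on the series, on what has been measured and on what is new or still open speak of the compounds shown alone.

Measured compounds:
compound 1, `CCN(Cc1ccncc1)c1ccc(C(=O)N2CCc3ccc(OS(N)(=O)=O)cc3C2)cc1`: 47%
compound 2, `NS(=O)(=O)Oc1ccc2c(c1)CN(C(=O)c1ccc(N(CCCO)Cc3ccccc3)cc1)CC2`: 5.7%

In an assay on HEK293 cells for inhibition of Steryl-sulfatase (Homo sapiens), tested at 0.1 uM (on this read-out higher numbers stand for a stronger effect at the one concentration tested and lower numbers for a weaker effect), compound 2 gives 5.7%, the lowest of the two numbers. Compound 1 gives 47%, a number beyond the scatter above it, but the two structures differ in more than one place, so no single step can be read from that pair.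

Compound 3, `CCCN(Cc1ccccc1)c1ccc(C(=O)N2CCc3ccc(OS(N)(=O)=O)cc3C2)cc1`, has not been measured. It differs from compound 2 in one place: hydrogen in place of hydroxy on a saturated chain carbon, three bonds along the chain from a nitrogen on an aromatic ring. Going by the values given here, no measured pair isolates this change.

Compound 3 is expected to give about 15%, within 2% to 40%. The step of a number 9.3 percentage points higher from compound 2 to compound 3 (within the scatter) is expected to be a small rise, not clearly beyond the scatter.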

Compound 3, a percentage reported as inhibition, at one concentration (the size of the read-out at that concentration, not a potency): 64.8%
The estimate for compound 3 lay 49.8 percentage points below the measured number; the measured number lies above the stated range.
By their numbers in this assay, from the lowest: compound 2; then compound 1; then compound 3.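

Going from 3-hydroxypropyl to propyl on the aromatic nitrogen gives a number 59.1 percentage points higher from compound 2 to compound 3 (beyond the scatter) in this assay and shows that this single hydroxy, three bonds along the chain, separates a weak read-out from the highest of the series. Benzyl(propyl)amino in place of ethyl((pyridin-4-yl)methyl)amino gives a number 17.8 percentage points higher from compound 1 to compound 3 (beyond the scatter) and so counts for less than the loss of the hydroxy. Nothing available explains either step. As far as these compounds go, whether a methoxy group, an amine or a longer chain at this place would read like the hydroxy or like hydrogen stays open.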